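The source may report more compounds than this note shows. Statements on the series, on what has been measured and on what is new or still open speak of the compounds shown alone.

Compound 1 (`N/N=C(\S)[C@]1(c2cccnc2)CCCC[S+]1[O-]`) gives > 30000 nM in a functional assay (aorta) for inhibition, with Rattus norvegicus as the target (on this read-out higher numbers stand for weaker inhibition and lower numbers for stronger inhibition), as a limit, not a number. Compound 2 (`[O-][S+]1CCCC[C@]1(CS)c1cccnc1`) gives > 30000 nM as a limit, not a number. Compound 3 (`COC(=N)[C@]1(c2cccnc2)CCCC[S+]1[O-]`) gives > 30000 nM as a limit, not a number, so its standing is known only as a limit. Among the compounds with values here, the series so far is the limit of > 30000 nM in this assay, at which 3 of the 3 values shown sit, in every case.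

Compound 4 (`C/N=C(\SC)[C@]1(c2cccnc2)CCCC[S+]1[O-]`) carries, on a saturated ring carbon next to the ring sulfur, a group of 5 heavy atoms in place of the group of 4 heavy atoms in compound 3: a group of 5 heavy atoms (3 carbon, 1 nitrogen, 1 sulfur; no ring) in place of a group of 4 heavy atoms (2 carbon, 1 nitrogen, 1 oxygen; no ring), on a saturated ring carbon.

Within the data shown here, three measured steps bear on this change. These are a step that the two limits leave unreadable from compound 1 to compound 2 and a step that the two limits leave unreadable from compound 1 to compound 3 and a step that the two limits leave unreadable from compound 2 to compound 3 and none of them has a readable size. They offer no direction, so no step beyond the scatter is expected in this assay from this change. The estimated step is a number no higher from compound 3 to compound 4 (the limit leaves the size open) and another limit is the expected report. The estimated value for compound 4 is 30000 nM within an expected range of 6000 nM to 100000 nM in this series.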

Compound 4, concentration for 90% inhibition: > 30000 nM
Compound 4: no number, only a limit; the forecaster's own chance of this, stated with the estimate: 75%; the middle value sits exactly at the limit.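

In this assay compound 4 gives > 30000 nM, a limit and not a number. Its steps from compound 1, compound 2 and compound 3 cannot be read: the limit of > 30000 nM in this assay, at which 4 of the 4 values shown sit.

The compounds shown leave open how strongly any of these groups on the saturated ring carbon inhibits, since none gives a number.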